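The source may report more compounds than this note shows. Statements on the series, on what has been measured and on what is new or still open speak of the compounds shown alone.

Of the compounds shown here, three that share one core have been measured in an assay on isolated protein for binding affinity to histamine H2 receptor (Homo sapiens); on this read-out lower numbers stand for stronger inhibition and higher numbers for weaker inhibition. Compound 1 `CC(=O)c1ccc(OCCCN2CC[C@H](NC(=O)c3csc(-c4cccnc4)n3)C2)cc1` gives 6200 nM. Compound 2 `CC(=O)c1ccc(OCCCN2CC[C@H](NC(=O)[C@@H](N)CO)C2)cc1` gives 22000 nM. Compound 3 `CC(=O)c1ccc(OCCCN2CC[C@H](NS(=O)(=O)c3ccc(C#N)cc3)C2)cc1` gives 2300 nM. Among these three, compound 2 stands at the highest number: the two values of compound 1 and compound 2 show compound 1 lower, beyond the scatter, and the two values of compound 3 and compound 2 show compound 3 lower by a wider margin, also beyond the scatter.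

Compound 4 `CC(=O)c1ccc(OCCCN2CC[C@H](NC(=O)c3cccnc3)C2)cc1` has not yet been measured in this assay. The change from compound 2 is pyridin-3-yl in place of 1-amino-2-hydroxyethyl on a carbonyl carbon.

Within the data shown here, no step between measured compounds with a single difference is available, so the expectation rests on what the three values show. Because compound 1, which also carries an aromatic ring on the carbonyl carbon, gives 6200 nM, compound 4 is expected to land nearer that level than to compound 2, so the estimated step of a 4.0-fold lower number from compound 2 to compound 4 (0.60 log units; beyond the scatter) is a decrease beyond the scatter. Compound 4 is therefore estimated at 5500 nM, with a range from 1500 nM to 18000 nM.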

Compound 4, inhibition constant: 3500 nM
For compound 4 the middle estimate is 1.6-fold (0.20 log units) above the measured one, within the range that was stated.
By their numbers in this assay, from the lowest: compounds 3, 4 and 1 (each within the scatter of the next, the first and the last beyond it); then compound 2.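

In this assay, among these compounds, the exchange of 1-amino-2-hydroxyethyl for pyridin-3-yl on a carbonyl carbon gives a 6.3-fold lower number from compound 2 to compound 4 (0.80 log units; beyond the scatter) as the first single-place step that can be read at this position. It shows that this place responds to the group on the carbonyl carbon: the open group with its defined stereocentre and the six-membered aromatic ring with one hetero atom are not interchangeable here. Nothing measured in these compounds speaks to the origin of the step.

From the compounds shown here alone, whether the step follows from the arrival of the ring or from the loss of the amino and hydroxyl groups stays open, as this one change carries both. A phenyl ring, a pyridin-4-yl ring or a plain methyl group on the same carbonyl carbon would help to separate the two.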